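Dichlorophenyl for fluorophenyl in the diaryl guanidine series

A few compounds are considered here, and "the series" means these few. Any claim that something is new, unique, unknown or untested is made for them only; others in the source may bear on it.

Compound 1 `N=C(NCCCc1c[nH]cn1)NCCC(c1ccccc1)c1ccccn1` is the parent of this set, and in a functional assay on cardiac atrium for agonist activity at histamine H2 receptor (Cavia porcellus) (a higher number here means a more potent compound, by a factor of ten per unit of this negative logarithm, a lower number a less potent compound), compound 1 gives 7.39. Compound 2 `N=C(NCCCc1c[nH]cn1)NCCC(c1ccc(Cl)c(Cl)c1)c1ccccn1` gives 8.19 in this assay, and compound 3 `N=C(NCCCc1c[nH]cn1)NCCC(c1ccccc1)c1ccc(F)cc1` gives 7.73. Compound 3 thus stands second highest of the three, with compound 1 nearest and compound 2 furthest.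

Compound 4 `N=C(NCCCc1c[nH]cn1)NCCC(c1ccccc1)c1ccc(Cl)c(Cl)c1` is not yet measured. Relative to compound 3 the change is 3,4-dichlorophenyl in place of 4-fluorophenyl on a saturated chain carbon bound to an aromatic carbon and a saturated chain carbon.

Within the data shown here, two measured steps bear on this. The step of a number 0.80 log units higher from compound 1 to compound 2 (beyond the scatter) shows what the 3,4-dichlorophenyl brings when it replaces a plain phenyl at this position. The step of a number 0.34 log units higher from compound 1 to compound 3 (beyond the scatter) shows the 4-fluorophenyl bringing a smaller gain when it replaces pyridin-2-yl. Compound 4 differs from compound 3 by swapping the 4-fluorophenyl for the 3,4-dichlorophenyl, so the expected gain in this assay is positive but somewhat less than the full step from compound 1 to compound 2, since part of that gain is already present in compound 3.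

The expected step is a number 0.47 log units higher from compound 3 to compound 4 (beyond the scatter). Compound 4 is therefore estimated at 8.2, with a range from 7.7 to 8.7.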

Compound 4, negative logarithm of the half-maximal effective concentration: 7.46
The estimate for compound 4 lay 0.74 log units above the measured number, outside the stated range (below it).
By their numbers in this assay, from the lowest: compounds 1, 4 and 3 (each within the scatter of the next, the first and the last beyond it); then compound 2.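

Working notes on the 3,4-dichlorophenyl at this position: in this assay its effect depends on the other aryl group on the same saturated chain carbon, which the earlier compounds could not show. With the 3,4-dichlorophenyl held in place, phenyl in place of pyridin-2-yl gives a number 0.73 log units lower from compound 2 to compound 4 (beyond the scatter) and so removes the rise seen in a number 0.80 log units higher from compound 1 to compound 2 (beyond the scatter) when the 3,4-dichlorophenyl is paired with pyridin-2-yl. When phenyl is the partner, 3,4-dichlorophenyl in place of pyridin-2-yl gives a number 0.07 log units higher from compound 1 to compound 4 (within the scatter) and 3,4-dichlorophenyl in place of 4-fluorophenyl gives a number 0.27 log units lower from compound 3 to compound 4 (within the scatter) and neither exchange separates the compounds in this assay, so the gain of compound 2 belongs to the pairing of the two groups and not to the 3,4-dichlorophenyl alone.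

Nothing available here accounts for this dependence on the partner group.

Still open, going by these compounds, is whether the pairing effect extends to other partners such as pyridin-3-yl or thiophen-2-yl, and whether a single chlorine, as in 4-chlorophenyl, is enough for it. Also open, on these data alone, is how 4-fluorophenyl behaves when paired with pyridin-2-yl on the same carbon, which would show whether the pairing effect is peculiar to the 3,4-dichlorophenyl.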